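The compounds below may be only part of what the source reports. "The series", "measured", "known", "first", "only" and "open" are said of these compounds alone.

Measured so far, in an assay on isolated protein for inhibition of cathepsin S (Homo sapiens), read by fluorescence, with a stated time of 20 min; on this read-out higher numbers stand for weaker inhibition and lower numbers for stronger inhibition:
Compound 1, `N#CC1(NC(=O)[C@@H]2C[C@@H](S(=O)(=O)c3ccccc3)C[C@H]2C(=O)N2CC3CCC(C2)O3)CC1`: 1 nM
Compound 2, `CN1CCN(C(=O)[C@@H]2C[C@H](S(=O)(=O)c3ccccc3)C[C@H]2C(=O)NC2(C#N)CC2)CC1`: 2 nM
Compound 3, `N#CC1(NC(=O)[C@@H]2C[C@@H](S(=O)(=O)c3ccccc3)C[C@H]2C(=O)Nc2ccc(F)cc2)CC1`: 26 nM

Compound 3 stands highest of the three numbers, that is, it inhibits least. Compound 4, `N#CC1(NC(=O)[C@@H]2C[C@@H](S(=O)(=O)c3ccccc3)C[C@H]2C(=O)N2CC(O)C2)CC1`, differs from compound 3 by 3-hydroxyazetidin-1-yl in place of (4-fluorophenyl)amino on a carbonyl carbon. Among the compounds with values here, two measured steps bear on this: a 26-fold higher number from compound 1 to compound 3 (1.41 log units; beyond the scatter) and a 13-fold higher number from compound 2 to compound 3 (1.11 log units; beyond the scatter). In both, a non-aromatic ring on that carbonyl went with a much lower number than the (4-fluorophenyl)amino group. The 3-hydroxyazetidin-1-yl group is again a non-aromatic ring on that carbonyl, though a four-membered one without precedent here, so a large drop in this assay is expected for compound 4. Compound 4 is estimated at 3 nM, between 1 nM and 10 nM. The expected step is an 8.7-fold lower number from compound 3 to compound 4 (0.94 log units; beyond the scatter).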

Compound 4, half-maximal inhibitory concentration: 7 nM
Estimate against measurement, compound 4: 2.3-fold (0.37 log units) below; low and high end bracket the measured number.
By their numbers in this assay, from the lowest: compounds 1 and 2 (each within the scatter of the next); then compound 4; then compound 3.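

In this assay, the four-membered 3-hydroxyazetidin-1-yl still beats the (4-fluorophenyl)amino group on this carbonyl, giving a 3.7-fold lower number from compound 3 to compound 4 (0.57 log units; beyond the scatter), so the non-aromatic ring need not be six-membered to lower the number. It does not match the larger ring groups, though, with a 3.5-fold higher number from compound 2 to compound 4 (0.54 log units; beyond the scatter) and a 7.0-fold higher number from compound 1 to compound 4 (0.85 log units; beyond the scatter), so which non-aromatic ring sits here also matters. No measurement shown explains these differences.

As far as these compounds go, how azetidin-1-yl without the hydroxyl, or morpholin-4-yl, would compare on this carbonyl remains open.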